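The source may report more compounds than this note shows. Statements on the series, on what has been measured and on what is new or still open speak of the compounds shown alone.

For the measured compounds named here, compound 3 `O=c1ccc(-c2ccccc2)nn1CCCCNC(=S)Nc1cccc2ccccc12` is one of three compounds measured so far in a functional assay on the whole organism with Rattus norvegicus as the target, at a dose of 100 mg/kg; on this read-out lower numbers stand for less inhibition and higher numbers for more inhibition at the one dose given (going by the name of the read-out). In this assay compound 3 gives 42.3%, the second highest of the three numbers. Its nearest neighbour is compound 1 `C/N=C(/NC#N)NCCCn1nc(-c2ccccc2)ccc1=O`, which gives 40.5%, a gap within the usual scatter of repeated measurements; the furthest is compound 2 `CC/N=C(\S)NCCCCCn1nc(-c2ccccc2)ccc1=O`, which gives 66.4%, a gap beyond the scatter. Compound 4 `C=CCNC(=S)NCCCCn1nc(-c2ccccc2)ccc1=O` has not yet been measured. It differs from compound 3 in one place: allyl in place of naphthalen-1-yl on an amide-type nitrogen. Going by the values given here, the only measured step between near neighbours, a number 25.9 percentage points higher from compound 1 to compound 2 (beyond the scatter), alters a group on a saturated chain carbon rather than the group on the amide-type nitrogen, so it does not bear directly on the present change; it only shows that a single replacement can move the read-out by a modest amount. Among the compounds with values here, no measured pair shows what allyl in place of naphthalen-1-yl on this nitrogen does, so the expectation stays close to the starting point, with a wide band. Compound 4 is therefore expected to give about 50%, between 32% and 68%. This amounts to an estimated step of a number 7.7 percentage points higher from compound 3 to compound 4 (within the scatter), which may well lie within the scatter.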

Compound 4, a percentage reported as inhibition, in the whole organism at one dose (the size of the read-out at that dose, not a potency): 27.1%
For compound 4 the middle estimate is 22.9 percentage points above the measured one, and the stated range ends above it.
By their numbers in this assay, from the lowest: compound 4; then compounds 1 and 3 (each within the scatter of the next); then compound 2.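

In this assay, the group on the amide-type nitrogen proves able to move the read-out on its own: allyl in place of naphthalen-1-yl gives a number 15.2 percentage points lower from compound 3 to compound 4 (beyond the scatter), a modest change. Compound 4 now has the lowest number of the four, with a number 39.3 percentage points lower from compound 2 to compound 4 (beyond the scatter) and a number 13.4 percentage points lower from compound 1 to compound 4 (beyond the scatter), although these two steps replace a whole group on the saturated chain and so do not isolate the effect of allyl. Nothing available explains why the number falls with this change.

For the compounds shown here, with only two groups compared directly at this nitrogen, it remains open whether the fall follows the loss of the aromatic rings or is specific to allyl. A phenyl or cyclohexyl group here, on the same chain and core, would help separate these possibilities.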